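This account rests on a few compounds, and the source may have more. Where it says the series, first, only, none or still open, it means among the compounds named here.

Measured compounds:

Compound 1 `O=C(Nc1ccc2[nH]cc(C3CCN(CCCN4CCC(c5c[nH]c6ccc(NC(=O)c7ccc(F)cc7)cc56)CC4)CC3)c2c1)c1ccc(F)cc1` in an assay on CHO-K1 cells for displacement of a labelled ligand from 5-hydroxytryptamine receptor 1B (Homo sapiens), read by scintillation counting (on this read-out lower numbers stand for stronger inhibition and higher numbers for weaker inhibition), gives > 10000 nM, a limit of the assay and not a number.
Compound 2 `O=C(Nc1ccc2[nH]cc(C3CCN(CCCCCCCCCCCCN4CCC(c5c[nH]c6ccc(NC(=O)c7ccc(F)cc7)cc56)CC4)CC3)c2c1)c1ccc(F)cc1` in this assay gives > 10000 nM, likewise a limit.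
Compound 3 `CCCCCCCCN1CCC(c2c[nH]c3ccc(NC(=O)c4ccc(F)cc4)cc23)CC1` in this assay gives > 1000 nM, again a limit.

None of the three compounds therefore has a measured inhibition constant. Compound 3 sits at the limit of > 1000 nM in this assay, at which 1 of the 3 values shown sits, while compound 1 and compound 2 sit at the limit of > 10000 nM in this assay, at which 2 of the 3 values shown sit; whether compound 3 differs from the other two cannot be read from limits. The step to compound 4 `O=C(Nc1ccc2[nH]cc(C3CCN(CCN4CCCCC4)CC3)c2c1)c1ccc(F)cc1` is piperidin-1-yl in place of hexyl on a saturated chain carbon, two bonds along the chain from an amine nitrogen in a ring, so the chain on the ring amine nitrogen becomes shorter and carries a second ring amine at its end. Going by the values given here, no measured step among the three compounds resembles this change, so no direction can be drawn from them; all that is known is that compound 3 gives no number in this assay. The estimate for compound 4 in this assay is 1500 nM, with a range from 200 nM to 10000 nM, which is expected to mean a step that the limit leaves unreadable from compound 3 to compound 4 from compound 3, though a limit rather than a number is about as likely as not.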

Compound 4, inhibition constant: > 1000 nM
Compound 4: no number, only a limit (the forecaster's own chance of this, stated with the estimate: 45%); the middle value lies beyond the limit too.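

Going by these compounds alone, compound 3 and compound 4 both give only a limit in this assay, so no step between them can be read. The compounds shown leave open what inhibition constant any of them has, and whether piperidin-1-yl in place of hexyl shifts it at all.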